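Nitro for methyl on the amide ring: cytotoxicity outlook

The source may hold more compounds than are shown below. What is called first, only, known or untested is meant among the compounds shown, and "the series" means these compounds.

Of the compounds shown here, three have been measured in an ADME assay on J774 cells (Mus musculus, strain BALB/c) for cytotoxicity, read by resazurin assay, with a stated time of 72 h; a higher number here means that more compound is tolerated, a lower number that less compound is tolerated. Compound 1 `CC(/C=N/Nc1ccc([N+](=O)[O-])cc1)=N\NC(=O)c1ccc(O)cc1` gives 51000 nM. Compound 2 `CC(/C=N/Nc1ccc([N+](=O)[O-])cc1)=N\NC(=O)c1ccc(C(F)(F)F)cc1` gives 78700 nM. Compound 3 `CC(/C=N/Nc1ccc([N+](=O)[O-])cc1)=N\NC(=O)c1cccc(C)c1` gives > 100000 nM, which is a limit of this assay and not a number; it sits at the limit of > 100000 nM in this assay, at which 1 of the 3 values shown sits. The step of a 1.5-fold higher number from compound 1 to compound 2 (0.19 log units; within the scatter) and the step of an at least 1.9-fold higher number from compound 1 to compound 3 (0.29 log units; that floor lies within the scatter) both stay within the scatter, so on the numbers shown compound 3 stands no lower than the other two, but no order among the three is established.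

Compound 4 `CC(/C=N/Nc1ccc([N+](=O)[O-])cc1)=N\NC(=O)c1ccc([N+](=O)[O-])cc1` has not been measured. It differs from compound 3 by 4-nitrophenyl in place of 3-methylphenyl on a carbonyl carbon. For the measured compounds named here, no measured step makes this exact exchange; the two steps measured on the same ring, one exchanging a substituent and one exchanging the whole ring, both lay within the scatter in this assay. On that basis the step from compound 3 to compound 4 is expected to be an at least 1.1-fold lower number from compound 3 to compound 4 (0.04 log units; that floor lies within the scatter), with no change beyond the scatter. Compound 4 is therefore estimated at 90000 nM in this assay, with a range of 40000 nM to 200000 nM, and a fair chance that only a limit is reported again.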

Compound 4, half-maximal cytotoxic concentration: > 100000 nM
Compound 4 was reported as a limit; the forecaster's own chance of this, stated with the estimate: 45%; middle value at least 1.1-fold (0.04 log units) from the limit.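

In this assay compound 4 gives > 100000 nM, which is a limit and not a number, so 4-nitrophenyl on the carbonyl carbon ends at the same assay ceiling as 3-methylphenyl: the limit of > 100000 nM in this assay, at which 2 of the 4 values shown sit.

For the compounds shown here, this is the first sign that the amide ring can carry nitro without a measurable fall in the number, although the readings against the other ring substituents are an at least 1.2-fold higher number from compound 2 to compound 4 (0.10 log units; that floor lies within the scatter) and an at least 1.9-fold higher number from compound 1 to compound 4 (0.29 log units; that floor lies within the scatter), so neither separates compound 4 from compound 2 or compound 1. The step between compound 3 and compound 4 cannot be read, as both stand only as limits, and the exchange of 3-methylphenyl for 4-nitrophenyl therefore has no size in these notes.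

Still open, on these data alone, is where compound 3 and compound 4 truly lie beyond the limit, and whether any group on this ring moves the number beyond the scatter. An amine or a carboxylic acid on the ring, or a longer chain on the carbonyl carbon in place of the ring, would test whether this position tolerates more than the four groups shown here.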